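Lengthening the carboxy chain of compound 2

The source may hold more compounds than are shown below. What is called first, only, known or untested is meant among the compounds shown, and "the series" means these compounds.

- compound 1 `O=S(=O)(c1cccc(C(F)(F)F)c1)n1ccc2ccc(-c3cc(F)cc(OC(F)F)c3)cc21`: 0.652 h
- compound 2 `O=C(O)CC1Cc2ccc(-c3cc(F)cc(OC(F)F)c3)cc2N1S(=O)(=O)c1cccc(C(F)(F)F)c1`: 1.88 h

In an ADME assay on microsomes from liver (Mus musculus) for metabolic stability, read by LC-MS, using NADPH, with a stated time of 60 min, tested at 1 uM (on this read-out higher numbers stand for a longer-lived compound and lower numbers for a shorter-lived compound), compound 2 stands higher of the two at 1.88 h, and its gap to compound 1 lies beyond the usual scatter. Compound 3 `O=C(O)CCCC1Cc2ccc(-c3cc(F)cc(OC(F)F)c3)cc2N1S(=O)(=O)c1cccc(C(F)(F)F)c1` has not yet been measured. It differs from compound 2 in one place: 2-carboxyethyl in place of carboxy on a saturated chain carbon bound to a saturated ring carbon. Here, 2-carboxyethyl replaces carboxy on a saturated chain carbon bound to a saturated ring carbon. Among the measured compounds shown here, no measured pair shows a change of this kind, so no clear shift in either direction is expected in this assay. The estimated step is a 1.2-fold lower number from compound 2 to compound 3 (0.07 log units; within the scatter), which stays within the scatter. Compound 3 is expected at 1.6 h, within an estimated range of 0.7 h to 3.6 h.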

Compound 3, half-life: 1.56 h
For compound 3 the middle estimate is 1.0-fold (0.01 log units) above the measured one, and the stated range covers the measured number.
By their numbers in this assay, from the lowest: compound 1; then compounds 3 and 2 (each within the scatter of the next).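

In this assay, putting 2-carboxyethyl in place of carboxy on a saturated chain carbon bound to a saturated ring carbon gives a 1.2-fold lower number from compound 2 to compound 3 (0.08 log units; within the scatter) and so leaves the half-lives of these two compounds indistinguishable. At this position, then, the longer chain with its carboxy end is tolerated in this read-out, at least at this length. Nothing measured here accounts for this result.

Still open, as far as these compounds go, is whether a longer chain would also fit this pattern. The effect of an amine or a primary amide at the chain end is also unknown.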